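Removing a methoxy from the curcuminoid-type series

The source may report more compounds than this note shows. Statements on the series, on what has been measured and on what is new or still open speak of the compounds shown alone.

Measured in a functional assay on HepG2 cells (Homo sapiens) for cytotoxicity, read by crystal violet staining, with a stated time of 72 h; a lower number here means a stronger inhibitor, a higher number a weaker inhibitor:
compound 1 `COc1cc(/C=C/C(=O)/C=C(O)/C=C/c2ccc(O[C@]3(C)C=C[C@@H]([C@@H](C)CCC=C(C)C)C[C@@H]3O)c(OC)c2)ccc1O` gives 35900 nM
compound 2 `COc1cc(/C=C/C(=O)/C=C(O)/C=C/c2ccc(O[C@]3(C)C=C[C@@H]([C@@H](C)CC(=O)C=C(C)C)C[C@@H]3O)c(OC)c2)ccc1O` gives 15700 nM

Among the measured compounds shown here, compound 2 holds the lowest of the two numbers; the one step measured, a 2.3-fold lower number from compound 1 to compound 2 (0.36 log units; beyond the scatter), concerns the chain, not the aromatic ring. Compound 3 `COc1cc(/C=C/C(=O)/C=C(O)/C=C/c2ccc(O[C@]3(C)C=C[C@@H]([C@@H](C)CC(=O)C=C(C)C)C[C@@H]3O)cc2)ccc1O` differs from compound 2 by hydrogen in place of methoxy on an aromatic carbon. For the measured compounds named here, no measured step bears on this change, so nothing beyond the scatter is expected in this assay. Compound 3 is therefore estimated at 16000 nM (range 6000 nM to 45000 nM), an expected step of a 1.0-fold higher number from compound 2 to compound 3 (0.01 log units; within the scatter) from the value of compound 2.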

Compound 3, half-maximal inhibitory concentration: 17100 nM
Compound 3: the middle estimate sits 1.1-fold (0.03 log units) below what was measured; the range from low to high includes it.
By their numbers in this assay, from the lowest: compounds 2 and 3 (each within the scatter of the next); then compound 1.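

In this assay, hydrogen in place of methoxy on this aromatic carbon, ortho to a large group and meta to a large group, gives a 1.1-fold higher number from compound 2 to compound 3 (0.04 log units; within the scatter). Among the compounds shown here, the methoxy is therefore dispensable at this position in compound 2, whereas the only earlier step, a 2.3-fold lower number from compound 1 to compound 2 (0.36 log units; beyond the scatter), concerned the chain and did not test the aromatic ring.

From the compounds shown here alone, whether an amine, a fluorine or an ethoxy on this carbon would shift the number remains open, as does the effect of the same removal on the other aromatic ring. No available evidence bears on this result.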